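The compounds below may be only part of what the source reports. "The series", "measured", "known", "first", "only" and "open" are said of these compounds alone.

In an ADME assay on HepG2 cells (Homo sapiens) for cytotoxicity, read by MTT assay, with a stated time of 48 h (a lower number here means a stronger inhibitor, a higher number a weaker inhibitor), three compounds with a shared core have been measured. Compound 1, `O=S(=O)(c1ccc(-c2ccc3ncnc(Nc4ccc(OCc5ccccc5)c(Cl)c4)c3c2)cc1)N1CCOCC1`, gives > 15000 nM, which is a limit of the assay and not a number. Compound 2, `O=S(=O)(c1ccc(-c2ccc3ncnc(Nc4ccc(OCc5cccc(Cl)c5)c(Cl)c4)c3c2)cc1)N1CCOCC1`, gives > 15000 nM, again a limit. Compound 3, `O=S(=O)(c1ccc(-c2ccc3ncnc(Nc4ccc(OCc5ccc(C(F)(F)F)c(F)c5)c(Cl)c4)c3c2)cc1)N1CCOCC1`, gives > 15000 nM, also a limit. Compound 3 therefore stands with the other two, as the limit of > 15000 nM in this assay, at which 3 of the 3 values shown sit, shows.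

Compound 4, `O=S(=O)(c1ccc(-c2ccc3ncnc(Nc4ccc(OCc5cc(F)cc(F)c5F)c(Cl)c4)c3c2)cc1)N1CCOCC1`, differs from compound 3 in one place: 2,3,5-trifluorophenyl in place of 3-fluoro-4-(trifluoromethyl)phenyl on a saturated chain carbon bound to an oxygen on an aromatic ring. In words, 2,3,5-trifluorophenyl replaces 3-fluoro-4-(trifluoromethyl)phenyl on a saturated chain carbon bound to an oxygen on an aromatic ring.

The closest measured changes alter this same group, giving a step that the two limits leave unreadable from compound 1 to compound 3 and a step that the two limits leave unreadable from compound 2 to compound 3, while a single added chloro gives a step that the two limits leave unreadable from compound 1 to compound 2. None of these has a readable size. Among the compounds with values here, with the limit of > 15000 nM in this assay, at which 3 of the 3 values shown sit, as the only guide, no step of known size or direction is expected in this assay. The estimated change is a step that the limit leaves unreadable from compound 3 to compound 4, and it carries little weight. For compound 4 the expected value is 20000 nM, with an estimated range of 12000 nM to 40000 nM, and a report of only a limit is the likeliest outcome.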

Compound 4, half-maximal inhibitory concentration: > 3000 nM
Compound 4 was reported as a limit; the forecaster's own chance of this, stated with the estimate: 85%; the middle value is on the limit's open side.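

Within the data shown here, compound 1, compound 2, compound 3 and compound 4 are all reported only as limits, not as numbers, so no step from any of them to compound 4 can be read. The compounds shown leave open whether swapping these aromatic groups changes the value in this assay at all.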